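Replacing the 4-ethylpiperazin-1-yl group on an aromatic carbon

The source may report more compounds than this note shows. Statements on the series, on what has been measured and on what is new or still open speak of the compounds shown alone.

Among the compounds with values here, in a functional assay on MGC-803 cells (Homo sapiens) for inhibition, read by MTT assay, with a stated time of 72 h (a lower number here means a stronger inhibitor, a higher number a weaker inhibitor), compound 1 `CCN1CCN(c2cc(C(F)(F)F)nc(SCc3ccc(C(F)(F)F)cc3)n2)CC1` gives 25600 nM and stands highest of the two numbers so far. Compound 2 `Cc1nnc(Sc2cc(C(F)(F)F)nc(SCc3ccc(C(F)(F)F)cc3)n2)s1` gives 11400 nM and stands lower. Compound 3 `FC(F)(F)c1ccc(CSc2nc(SC3=NCCS3)cc(C(F)(F)F)n2)cc1` keeps the core of compound 1 but changes one group (a group of 6 heavy atoms (3 carbon, 1 nitrogen, 2 sulfur; one five-membered non-aromatic ring with 2 hetero atoms) in place of a group of 8 heavy atoms (6 carbon, 2 nitrogen; one six-membered non-aromatic ring with 2 hetero atoms), on an aromatic carbon). Within the data shown here, the only measured step that also removes 4-ethylpiperazin-1-yl is a 2.2-fold lower number from compound 1 to compound 2 (0.35 log units; beyond the scatter) and it is modest. A different group enters here, so only a similar modest step to a lower number is expected in this assay for compound 3 too. The estimated value for compound 3 is 13000 nM with an expected range of 5500 nM to 30000 nM around it. This estimate means a 2.0-fold lower number from compound 1 to compound 3 (0.29 log units; within the scatter) as the expected change.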

Compound 3, half-maximal inhibitory concentration: 24500 nM
The estimate for compound 3 lay 1.9-fold (0.28 log units) below the measured number; low and high end bracket the measured number.
By their numbers in this assay, from the lowest: compound 2; then compounds 3 and 1 (each within the scatter of the next).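

In this assay, the new five-membered ring and 4-ethylpiperazin-1-yl cannot be told apart, with a 1.0-fold lower number from compound 1 to compound 3 (0.02 log units; within the scatter) as their step, so not every replacement at this place shifts the number. Among the two sulfur-linked rings, the result is a 2.1-fold higher number from compound 2 to compound 3 (0.33 log units; beyond the scatter) in this assay, which suggests that the identity of the ring attached through sulfur can matter here. No measurement shown gives a reason for this difference. On these data alone, whether a carboxylic acid or a simple amine on this aromatic carbon would move the number further remains open, as does the role of the methyl on the ring of compound 2.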